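Aryl amide variations on a dichlorophenyl enone core

The source may report more compounds than this note shows. Statements on the series, on what has been measured and on what is new or still open speak of the compounds shown alone.

Measured so far:
compound 1, `C=C(CC)C(=O)c1ccc(OCC(=O)Nc2ccc(C(N)=O)cc2)c(Cl)c1Cl`: 3700 nM
compound 2, `C=C(CC)C(=O)c1ccc(OCC(=O)Nc2ccc3nc[nH]c3c2)c(Cl)c1Cl`: 3200 nM
compound 3, `C=C(CC)C(=O)c1ccc(OCC(=O)Nc2ccc(O)c(Cl)c2)c(Cl)c1Cl`: 5500 nM

All three values come from a functional assay on CLL cells (Homo sapiens) for cytotoxicity, read by MTT assay, with a stated time of 48 h; on this read-out lower numbers stand for an effect already at smaller amounts and higher numbers for an effect only at larger amounts of compound. Compound 1 lies within the scatter of both neighbours: a 1.2-fold lower number from compound 1 to compound 2 (0.06 log units; within the scatter) and a 1.5-fold higher number from compound 1 to compound 3 (0.17 log units; within the scatter), and between the other two the gap is a 1.7-fold higher number from compound 2 to compound 3 (0.24 log units; within the scatter). Each of these steps swaps the whole aryl group on the amide-type nitrogen, and none of them moves the read-out beyond the scatter.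

Compound 4, `C=C(CC)C(=O)c1ccc(OCC(=O)Nc2ccc(/C=C/C(=O)NO)cc2)c(Cl)c1Cl`, keeps the phenyl on the amide-type nitrogen and changes only its substituent: 2-(hydroxycarbamoyl)ethenyl in place of carbamoyl on an aromatic carbon. For the measured compounds named here, no measured step alters a substituent on this ring while keeping the ring itself, so the three swaps above are the only guide; their small size gives no reason to expect a large shift. The step from compound 1 to compound 4 is therefore expected to be a 1.3-fold lower number from compound 1 to compound 4 (0.12 log units; within the scatter), within the scatter. Compound 4 is estimated at 2800 nM in this assay, with a range from 900 nM to 8500 nM.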

Compound 4, half-maximal effective concentration: 2600 nM
For compound 4 the middle estimate is 1.1-fold (0.03 log units) above the measured one, and the stated range covers the measured number.
By their numbers in this assay, from the lowest: compounds 4, 2, 1 and 3 (each within the scatter of the next, the first and the last beyond it).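

For the compounds shown here, the change from carbamoyl to 2-(hydroxycarbamoyl)ethenyl is the first made on the phenyl ring itself, para to a large group, and in this assay it gives (a 1.4-fold lower number from compound 1 to compound 4 (0.15 log units; within the scatter)). At this position, the read-out therefore stays within the scatter with a substituent that has more heavy atoms, an added double bond outside the ring, and more hydrogen-bond donors and acceptors than carbamoyl. No measurement available here explains this lack of separation between the two compounds.

The compounds shown leave open whether a carboxylic acid, an amine or a longer chain at this position would also stay within the scatter. They also do not show whether the ethenyl link or the hydroxycarbamoyl end matters on its own, since the two enter together.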